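Ring substituent swap: methyl replacing phenoxy

A few compounds are considered here, and "the series" means these few. Any claim that something is new, unique, unknown or untested is made for them only; others in the source may bear on it.

Measured so far in a functional assay on HT-29 cells (Homo sapiens) for antiproliferative activity, read by sulforhodamine B assay, with a stated time of 48 h; a lower number here means a stronger inhibitor, a higher number a weaker inhibitor:
compound 1 `Cc1ccccc1NS(=O)(=O)c1ccc(N2CCNC2=O)cc1` gives 200 nM
compound 2 `COc1ccccc1NS(=O)(=O)c1ccc(N2CCNC2=O)cc1` gives 550 nM
compound 3 `O=C1NCCN1c1ccc(S(=O)(=O)Nc2cccc(Oc3ccccc3)c2)cc1` gives 200 nM

Compound 3 stands level with compound 1, the two together the lowest of the three numbers; compound 2 gives a higher number than compound 3. Within the data shown here, the one measured step, a 2.8-fold higher number from compound 1 to compound 2 (0.44 log units; beyond the scatter), is modest and swaps one small group for another on the same ring.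

Compound 4 `Cc1cccc(NS(=O)(=O)c2ccc(N3CCNC3=O)cc2)c1` differs from compound 3 by methyl in place of phenoxy on an aromatic carbon. Among the measured compounds shown here, no measured step removes a phenoxy, so the change has no direct counterpart. Compound 1, which also carries a methyl on this ring, matches compound 3, so compound 4 is expected to sit close: the expected step is a 1.5-fold higher number from compound 3 to compound 4 (0.18 log units; within the scatter), none beyond the scatter. Compound 4 is estimated at 300 nM, range 120 nM to 800 nM.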

Compound 4, half-maximal inhibitory concentration: 110 nM
The estimate for compound 4 lay 2.7-fold (0.44 log units) above the measured number, outside the stated range (below it).
By their numbers in this assay, from the lowest: compounds 4, 1 and 3 (each within the scatter of the next); then compound 2.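

In this assay, phenoxy on this aromatic carbon can give way to methyl with no step beyond the scatter (a 1.8-fold lower number from compound 3 to compound 4 (0.26 log units; within the scatter)), so the aromatic ring of the phenoxy is not needed to hold the number in this range. 3-Methylphenyl in place of 2-methylphenyl on the sulfonamide nitrogen also stays within the scatter (a 1.8-fold lower number from compound 1 to compound 4 (0.26 log units; within the scatter)), whereas 3-methylphenyl in place of 2-methoxyphenyl goes beyond it (a 5.0-fold lower number from compound 2 to compound 4 (0.70 log units; beyond the scatter)). No evidence is available on what lies behind these steps.

As far as these compounds go, whether an amine or a carboxylic acid on this carbon would hold the number remains open.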